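The compounds below may be only part of what the source reports. "The series", "measured", "known", "first", "only" and "open" are said of these compounds alone.

Measured so far in a functional assay on HeLa cells (Homo sapiens) for inhibition, read by CCK-8 assay, with a stated time of 48 h; on this read-out higher numbers stand for weaker inhibition and lower numbers for stronger inhibition:
- Compound 1 `COc1cc(-c2cc3nccc(-c4cc(OC)c(OC)c(OC)c4)n3n2)cc(OC)c1OC`: > 10000 nM (a limit of the assay, not a number)
- Compound 2 `COc1cc(-c2ccnc3cc(-c4cn(CO)c5ccccc45)nn23)cc(OC)c1OC`: 103 nM
- Compound 3 `COc1cc(-c2ccnc3cc(-c4ccc(Cl)cc4)nn23)cc(OC)c1OC`: 1490 nM

Of the two actual numbers in this assay, compound 3 has the higher one, 1490 nM, while compound 2 gives 103 nM, a gap beyond the usual scatter. Compound 4 `COc1cc(-c2ccnc3cc(-c4ccc5c(ccn5C)c4)nn23)cc(OC)c1OC` carries 1-methyl-1H-indol-5-yl in place of the 4-chlorophenyl of compound 3, on an aromatic carbon of a five-membered aromatic ring with 2 nitrogen (1-methyl-1H-indol-5-yl in place of 4-chlorophenyl on an aromatic carbon). Among the measured compounds shown here, the entering group resembles the one that compound 2 carries at that place, and compound 2 gives 103 nM, so a step to a lower number, beyond the scatter, is expected. The expected change is a 5.0-fold lower number from compound 3 to compound 4 (0.70 log units; beyond the scatter). For compound 4 the estimated value is 300 nM, with an expected range of 60 nM to 1500 nM.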

Compound 4, half-maximal inhibitory concentration: 19 nM
Estimate against measurement, compound 4: 16-fold (1.20 log units) above, outside the stated range (below it).
By their numbers in this assay, from the lowest: compound 4; then compound 2; then compound 3. At a limit, above all of these: compound 1.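

In this assay, among the compounds shown here, this step is the first direct reading of a single change at this position, the aromatic carbon of the five-membered ring: 1-methyl-1H-indol-5-yl in place of 4-chlorophenyl gives a 78-fold lower number from compound 3 to compound 4 (1.89 log units; beyond the scatter). The position therefore responds strongly to the group it carries, since one exchange moves the number far beyond the scatter. Nothing available here explains the size of this step.

Going by these compounds, what remains open is how the number would respond to an amine or a carboxylic acid on the indole, or to a longer chain in place of its 1-methyl group.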